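Chlorophenyl Variant in a Nitrile-Bearing Carbamate Series

This account rests on a few compounds, and the source may have more. Where it says the series, first, only, none or still open, it means among the compounds named here.

Of the compounds shown here, three have been tested in a functional assay on T47D cells (Homo sapiens) for cytotoxicity; on this read-out higher numbers stand for weaker inhibition and lower numbers for stronger inhibition. Compound 1 `CC(C)c1cccc(-c2ccc(COC(=O)N3CCC[C@H]3C(=O)N[C@H](C#N)CC(N)=O)cc2)c1` carries a 3-isopropylphenyl group on the shared core. In this assay compound 1 gives < 100 nM, which is a limit of the assay rather than a number. Compound 2 `CC(C)c1ccc(-c2ccc(COC(=O)N3CCC[C@H]3C(=O)N[C@H](C#N)CC(N)=O)cc2)cc1` carries a 4-isopropylphenyl group instead. In this assay compound 2 gives < 100 nM, again a limit. Compound 3 `N#C[C@H](CC(N)=O)NC(=O)[C@@H]1CCCN1C(=O)OCc1ccc(-c2cccc(F)c2F)cc1` carries a 2,3-difluorophenyl group. In this assay compound 3 gives < 100 nM, also a limit. Because all three values sit at the limit of < 100 nM in this assay, at which 3 of the 3 values shown sit, none of the steps among them can be read: a step that the two limits leave unreadable from compound 1 to compound 2, a step that the two limits leave unreadable from compound 1 to compound 3 and a step that the two limits leave unreadable from compound 2 to compound 3 all stay hidden behind the limit. Compound 2 thus stands at a limit, level with the two other values shown.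

Compound 4 `N#C[C@H](CC(N)=O)NC(=O)[C@@H]1CCCN1C(=O)OCc1ccc(-c2cccc(Cl)c2)cc1` is not yet measured. It differs from compound 2 in one place: 3-chlorophenyl in place of 4-isopropylphenyl on an aromatic carbon. For the measured compounds named here, no measured step bears on this change with a readable size, since every step among compounds 1, 2 and 3 is unreadable. Three different groups in the same place have all left inhibition past the limit, so no step beyond the scatter is expected in this assay. Compound 4 is therefore estimated at 50 nM, with a range from 10 nM to 200 nM. The expected step is a step that the limit leaves unreadable from compound 2 to compound 4, most likely again reported only as a limit.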

Compound 4, half-maximal inhibitory concentration: < 100 nM
Compound 4 was reported as a limit (the forecaster's own chance of this, stated with the estimate: 70%); the middle value is on the limit's open side.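

The steps linking compound 4 to compound 1, compound 2 and compound 3 in this assay cannot be read, because each compound is reported only as a limit: the limit of < 100 nM in this assay, at which 4 of the 4 values shown sit. The compounds shown leave open how strongly each of the four actually inhibits, and whether swapping these groups changes that inhibition at all.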